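Hydrazone aryl swap: pyridin-3-yl after 3-methoxyphenyl

This account rests on a few compounds, and the source may have more. Where it says the series, first, only, none or still open, it means among the compounds named here.

Among the measured compounds shown here, compound 2 `COc1cccc(/C=N/NC(=O)c2cccnc2Nc2cccc(C(F)(F)F)c2)c1` stands at the bottom of the two numbers measured so far in a functional assay on the whole organism (strain Wistar) for inhibition, with Rattus norvegicus as the target, read by paw edema, with a stated time of 4 h, at a dose of 10 mg/kg by the intraperitoneal route; a lower number here means less inhibition, a higher number more inhibition at the dose given (going by the name of the read-out): compound 2 gives 14.9%, whereas compound 1 `O=C(N/N=C/c1ccc(Cl)cc1)c1cccnc1Nc1cccc(C(F)(F)F)c1` gives 43.7%. For the measured compounds named here, the only measured step, a number 28.8 percentage points lower from compound 1 to compound 2 (beyond the scatter), comes with an exchange of the ring on the carbon with a double bond to nitrogen and lies beyond the scatter.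

Compound 3 `O=C(N/N=C/c1cccnc1)c1cccnc1Nc1cccc(C(F)(F)F)c1` has not been measured. It differs from compound 2 as follows: pyridin-3-yl in place of 3-methoxyphenyl on a carbon with a double bond to nitrogen. Going by the values given here, no measured step covers a pyridin-3-yl at this carbon. Among the compounds with values here, the one step that bears on the question, a number 28.8 percentage points lower from compound 1 to compound 2 (beyond the scatter), shows only that changing the ring at this place can move the read-out by a modest amount, and the pyridin-3-yl ring matches neither of the two rings measured, so the direction is open. The read-out of compound 3 is therefore expected to fall between the two measured numbers, with the step of a number 13.1 percentage points higher from compound 2 to compound 3 (beyond the scatter) estimated as a rise that may or may not exceed the scatter. Compound 3 is estimated at 28%, within a range from 8% to 50%.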

Compound 3, a percentage reported as inhibition, in the whole organism at one dose (the size of the read-out at that dose, not a potency): 36%
For compound 3 the middle estimate is 8 percentage points below the measured one, within the range that was stated.
By their numbers in this assay, from the lowest: compound 2; then compounds 3 and 1 (each within the scatter of the next).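

Working notes on the ring on the carbon with a double bond to nitrogen. Exchanging 3-methoxyphenyl for pyridin-3-yl gives a number 21.1 percentage points higher from compound 2 to compound 3 (beyond the scatter) in this assay and shows that the low number does not follow from every change of ring at this place. The exchange of 4-chlorophenyl for pyridin-3-yl gives a number 7.7 percentage points lower from compound 1 to compound 3 (within the scatter) in this assay and so separates neither ring from the other, which leaves compound 2, with 3-methoxyphenyl, alone as the lowest of the three and the exception among them. Nothing measured here accounts for these differences between the rings at this position.

Compound 1 and compound 2 differ in both the substituent and where it stands on the ring, so 3-chlorophenyl and 4-methoxyphenyl would be needed to tell whether the low number of compound 2 goes with the methoxy group or with its placement. The compounds shown also leave open how pyridin-4-yl, or a phenyl ring carrying a carboxylic acid or an amine, would read at this carbon, and all of these numbers remain readings at one dose, not potencies.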